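This account rests on a few compounds, and the source may have more. Where it says the series, first, only, none or still open, it means among the compounds named here.

Compound 1, `O=C1C=CC(OCC(F)(F)F)N1c1cc(Cl)cc(Cl)c1`: 1640 nM
Compound 2, `O=C1C=CC(OCC(F)(F)F)N1c1ccccc1`: 24600 nM
Compound 3, `O=C1C=CC(OCC(F)(F)F)N1c1ccc(Cl)cc1F`: 6210 nM

Of the compounds shown here, three that share one core have been measured in a functional assay on K562 cells (Homo sapiens) for inhibition; on this read-out higher numbers stand for weaker inhibition and lower numbers for stronger inhibition. Among them compound 3 stands second highest of the three numbers: compound 1 lies a good way lower, beyond the scatter, and compound 2 lies a similar way higher, also beyond the scatter. The next compound, compound 4 `O=C1C=CC(OCC(F)(F)F)N1c1ccccc1F`, has not yet been measured in this assay. It differs from compound 3 in one place: hydrogen in place of chloro on an aromatic carbon. Going by the values given here, no step between two measured compounds matches this change, so its size can only be judged from the values at hand. Compound 2 carries no substituent on that ring, and in this assay compound 2 gives 24600 nM, while compound 1 with its chloro groups gives 1640 nM. Compound 4, which keeps only the fluoro group, is expected to move upward, with an estimated step of a 2.4-fold higher number from compound 3 to compound 4 (0.38 log units; beyond the scatter) that lies beyond the scatter. For compound 4 the estimate in this assay is 15000 nM, within a range from 5000 nM to 40000 nM.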

Compound 4, half-maximal inhibitory concentration: 12000 nM
For compound 4 the middle estimate is 1.3-fold (0.10 log units) above the measured one, and the stated range covers the measured number.
By their numbers in this assay, from the lowest: compound 1; then compounds 3 and 4 (each within the scatter of the next); then compound 2.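

In this assay, hydrogen in place of chloro on the aromatic carbon para to a large group gives a 1.9-fold higher number from compound 3 to compound 4 (0.29 log units; within the scatter), so at this position chloro and hydrogen cannot be told apart. Going by these compounds alone, the other single change, fluoro in place of hydrogen on an aromatic carbon, gives a 2.1-fold lower number from compound 2 to compound 4 (0.31 log units; beyond the scatter), a modest step but one that lies beyond the scatter, and it is the only change read here that clears it. No supporting evidence bears on why either step has the size it has.

The compounds shown leave open whether a methoxy group, an amine or a nitrile at this position would separate from chloro and hydrogen. They also leave open whether chloro counts for more elsewhere on the ring.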